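Series notes: amide-to-pyridyl exchange at the distal ring

The compounds below may be only part of what the source reports. "The series", "measured", "known", "first", "only" and "open" are said of these compounds alone.

Compound 2 `C=CC(=O)Nc1cccc(Nc2ncnc(Nc3ccc(C(=O)N4CCCCC4)cc3)n2)c1` is the reference here. Going by the values given here, in a functional assay on Ramos cells (Homo sapiens) for antiproliferative activity, read by CCK-8 assay, with a stated time of 24 h (on this read-out higher numbers stand for weaker inhibition and lower numbers for stronger inhibition), compound 2 gives 6140 nM, the lowest of the two numbers known so far. Among the compounds with values here, its nearest neighbour is compound 1 `C=CC(=O)Nc1cc(Nc2ncnc(Nc3ccc(C(=O)N4CCCCC4)cc3)n2)ccc1C`, which in this assay gives 48500 nM; the only measured step, a 7.9-fold lower number from compound 1 to compound 2 (0.90 log units; beyond the scatter), is a change of hydrogen for methyl on an aromatic carbon of the shared core and has nothing to do with the distal ring.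

Compound 3 `C=CC(=O)Nc1cccc(Nc2ncnc(Nc3ccc(-c4cccnc4)cc3)n2)c1` differs from compound 2 by the change (pyridin-3-yl in place of (piperidin-1-yl)carbonyl on an aromatic carbon). Within the data shown here, no measured pair in the set touches this position or exchanges an amide for an aromatic ring, so the step from compound 1 to compound 2 gives no guidance on direction or size. The change is therefore treated as uninformed: no movement beyond the scatter is assumed, and the range is kept wide in both directions.

On that basis compound 3 is expected to give about 6000 nM in this assay, within roughly 1500 nM to 25000 nM. The step of a 1.0-fold lower number from compound 2 to compound 3 (0.01 log units; within the scatter) is thus an estimate, not a measurement.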

Compound 3, half-maximal inhibitory concentration: > 100000 nM
Compound 3 gave a limit, no number; the forecaster's own chance of this, stated with the estimate: 10%; middle value at least 16-fold (1.22 log units) away from the limit.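

In this assay, the change to pyridin-3-yl in place of (piperidin-1-yl)carbonyl, on the aromatic carbon para to a large group, gives an at least 16-fold higher number from compound 2 to compound 3 (1.21 log units; beyond the scatter), so the read-out responds to this position, which the earlier step on the shared core left untouched. The change is not captured by the simple counts: both groups carry 0 hydrogen-bond donors and 1 hydrogen-bond acceptor, and each holds one six-membered ring with 1 hetero atom, so what separates them here is the carbonyl, the double bond outside aromatic rings, the heavy-atom count and the aromatic against non-aromatic ring. Compound 3 gives a limit of the assay and not a number, so the step has a lower bound but no full size: the limit of > 100000 nM in this assay, at which 1 of the 3 values shown sits.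

This single pair cannot tell whether the carbonyl, the piperidine ring or the entering aromatic ring accounts for the step. From the compounds shown here alone, how an open-chain dimethylamide, a carboxylic acid, a primary amine or an unsubstituted phenyl ring at this place would read in this assay remains open.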